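Piperidine in place of thiomorpholine on the thiocarbonyl carbon

A few compounds are considered here, and "the series" means these few. Any claim that something is new, unique, unknown or untested is made for them only; others in the source may bear on it.

Compound 1 `N/C(=N\NC(=S)N1CCOCC1)c1ccccn1`: 78.8%
Compound 2 `N/C(=N\NC(=S)N1CCSCC1)c1ccccn1`: 81.3%

In a functional assay on A-431 cells (Homo sapiens) for cytotoxicity, read by MTT assay, with a stated time of 72 h, tested at 30 uM (a higher number here means more inhibition of growth at the concentration tested, a lower number less inhibition of growth), compound 2 gives 81.3%, the higher of the two numbers measured, with compound 1 as its nearest neighbour; the step of a number 2.5 percentage points higher from compound 1 to compound 2 (within the scatter) lies within the scatter, so the two compounds cannot be told apart on these data. Compound 3 `N/C(=N\NC(=S)N1CCCCC1)c1ccccn1` differs from compound 2 in one place: piperidin-1-yl in place of thiomorpholin-4-yl on a thiocarbonyl carbon. For the measured compounds named here, the only measured step that bears on this change is the exchange of one six-membered saturated ring for another on the same thiocarbonyl carbon, a number 2.5 percentage points higher from compound 1 to compound 2 (within the scatter), which was within the scatter. A further exchange of this kind is therefore expected to move the number in this assay by no more than the scatter, in no particular direction, an expected step of a number 1.3 percentage points lower from compound 2 to compound 3 (within the scatter). Compound 3 is estimated at 80%, with a range from 66% to 92%.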

Compound 3, percent growth inhibition at one concentration: 79.7%
The estimate for compound 3 lay 0.3 percentage points above the measured number; measured number inside the range.
By their numbers in this assay, from the lowest: compounds 1, 3 and 2 (each within the scatter of the next).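

In this assay, taking the ring sulfur out gives a number 1.6 percentage points lower from compound 2 to compound 3 (within the scatter), and taking the ring oxygen out gives a number 0.9 percentage points higher from compound 1 to compound 3 (within the scatter). Compound 3 thus adds a ring with only 1 hetero atom and 0 hydrogen-bond acceptors to the two rings with 2 hetero atoms, and neither of its steps leaves the scatter. With all three steps on the thiocarbonyl carbon within the scatter, morpholin-4-yl, thiomorpholin-4-yl and piperidin-1-yl cannot be told apart on these data, so the second ring hetero atom shows no measurable consequence among these compounds.

As far as these compounds go, what a piperazine ring, a smaller pyrrolidine ring or an open-chain diethylamino group on the same carbon would give remains open. The data on hand offer no independent measurement that could account for how closely these three compounds agree.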